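The source may report more compounds than this note shows. Statements on the series, on what has been measured and on what is new or still open speak of the compounds shown alone.

In a functional assay on V79 cells (Cricetulus griseus) for cytotoxicity, read by colony formation (a higher number here means a weaker inhibitor, a lower number a stronger inhibitor), compound 1 (`CC1(CN)CCN(c2c(F)cc3c(=O)c(C(=O)O)cn(C4CC4)c3c2F)C1`) gives 8 ug/mL, and compound 2 (`COc1c(N2CCC(C)(CN)C2)c(F)cc2c(=O)c(C(=O)O)cn(C3CC3)c12`) gives 38 ug/mL. Going by the values given here, compound 2 therefore holds the higher of the two numbers so far, which makes it the weaker inhibitor of the pair. Compound 3 (`COc1c(N2CCC(C)(N)C2)c(F)cc2c(=O)c(C(=O)O)cn(C3CC3)c12`) keeps the core of compound 2 and changes only the side group: it carries amino in place of aminomethyl on a saturated ring carbon, turning 3-(aminomethyl)-3-methylpyrrolidin-1-yl into 3-amino-3-methylpyrrolidin-1-yl (amino in place of aminomethyl on a saturated ring carbon). Among the compounds with values here, only one measured step is available as a guide, a 4.8-fold higher number from compound 1 to compound 2 (0.68 log units; beyond the scatter). That modest step came from methoxy in place of fluoro on an aromatic carbon, a change at a different place in the molecule, so it gives no direct reading on the loss of aminomethyl. Within the data shown here, no measured pair isolates this new change, so no direction can be favoured and no step beyond the scatter is expected. The expected outcome is a 1.3-fold lower number from compound 2 to compound 3 (0.10 log units; within the scatter), and this estimate carries wide uncertainty. For compound 3, the estimated value in this assay is 30 ug/mL, with an expected range from 10 ug/mL to 90 ug/mL.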

Compound 3, half-maximal inhibitory concentration: 38 ug/mL
Estimate against measurement, compound 3: 1.3-fold (0.10 log units) below; the range from low to high includes it.
By their numbers in this assay, from the lowest: compound 1; then compounds 2 and 3 (each within the scatter of the next).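

In this assay, amino in place of aminomethyl on this saturated ring carbon gives no change at the digits printed from compound 2 to compound 3 (within the scatter) with the methoxy group kept on the core. Going by these compounds alone, the earlier pair spoke only to methoxy in place of fluoro on an aromatic carbon, whereas this pair gives the first reading at the ring carbon two ring bonds from the ring nitrogen: here, removing the carbon that separates the amine from the ring leaves the number within the scatter. Nothing available explains this result.

One pair on one core cannot show whether the same change would behave alike on the core of compound 1, which carries fluoro where compound 2 and compound 3 carry methoxy. The compounds shown also leave open what this ring carbon would tolerate beyond these two side groups, such as a longer chain like 2-aminoethyl, or hydroxymethyl, which has an oxygen where aminomethyl has its nitrogen.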